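A few compounds are considered here, and "the series" means these few. Any claim that something is new, unique, unknown or untested is made for them only; others in the source may bear on it.

Of the compounds shown here, three have been measured in a functional assay on A549 cells (Homo sapiens) for cytotoxicity, read by MTT assay, with a stated time of 72 h; on this read-out lower numbers stand for stronger inhibition and higher numbers for weaker inhibition. Compound 1 `O=C(CN1CCN(c2nnc(Cc3ccccc3)c3ccccc23)CC1)Nc1ccc(F)c(C(F)(F)F)c1` gives 2480 nM. Compound 2 `O=C(CN1CCN(c2nnc(Cc3ccncc3)c3ccccc23)CC1)Nc1ccc(F)c(C(F)(F)F)c1` gives 16000 nM, and compound 3 `O=C(CN1CCN(c2nnc(Cc3ccncc3)c3ccccc23)CC1)Nc1cc(C(F)(F)F)ccc1Cl` gives 1850 nM. Among these three numbers compound 1 holds the second highest; its value and that of compound 3 lie within the scatter of each other, while the step of a 6.5-fold higher number from compound 1 to compound 2 (0.81 log units; beyond the scatter) lies beyond it.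

Compound 4 `O=C(CN1CCN(c2nnc(Cc3ccccc3)c3ccccc23)CC1)Nc1cccc(Br)c1` differs from compound 1 in one place: 3-bromophenyl in place of 4-fluoro-3-(trifluoromethyl)phenyl on an amide-type nitrogen. For the measured compounds named here, only one measured step changes the group on the amide-type nitrogen: an 8.6-fold lower number from compound 2 to compound 3 (0.94 log units; beyond the scatter). The step of a 6.5-fold higher number from compound 1 to compound 2 (0.81 log units; beyond the scatter) concerns a different part of the molecule and does not bear on this change. Going by the values given here, no measured pair swaps the 4-fluoro-3-(trifluoromethyl)phenyl for 3-bromophenyl, so the direction remains uncertain; the single step at this position shows only that exchanging this group can move the number by a modest amount. For compound 4 a step of similar or smaller size is expected, a 1.4-fold higher number from compound 1 to compound 4 (0.15 log units; within the scatter), leaning toward a somewhat higher number. Compound 4 is therefore estimated at 3500 nM, with a range from 1200 nM to 10000 nM.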

Compound 4, half-maximal inhibitory concentration: "not active" (no number reported)
Nothing numeric was reported for compound 4; there is nothing to compare the estimate with.
By their numbers in this assay, from the lowest: compounds 3 and 1 (each within the scatter of the next); then compound 2.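

In this assay, for the compounds shown here, compound 4 is reported only as "not active", without a number, so no step from compound 1 to compound 4 can be read. The compounds shown leave open how far 3-bromophenyl in place of 4-fluoro-3-(trifluoromethyl)phenyl moves the number. No data shown here offer an explanation for this result.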